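This account rests on a few compounds, and the source may have more. Where it says the series, first, only, none or still open, it means among the compounds named here.

Values in a functional assay on HeLa cells (Homo sapiens) for inhibition, read by CCK-8 assay, with a stated time of 48 h (on this read-out lower numbers stand for stronger inhibition and higher numbers for weaker inhibition), are as follows:
- compound 1 `COc1ccc(Oc2ccc(C(C)C)cc2-c2ccsc2S(=O)(=O)NCCNC(=S)Nc2ccc([N+](=O)[O-])cc2)cc1OC` with 11900 nM measured
- compound 2 `COc1ccc(Oc2ccc(C(C)C)cc2-c2ccsc2S(=O)(=O)NCCNC(=O)Nc2cc(Cl)cc(Cl)c2)cc1OC` with 11600 nM measured

Compound 1 stands level with compound 2, their two numbers lying within the scatter of each other. Compound 3 `CC(C)c1ccc(Oc2ccc(O)c(O)c2)c(-c2ccsc2S(=O)(=O)NCCNC(=S)Nc2ccc([N+](=O)[O-])cc2)c1` differs from compound 1 by a single change (3,4-dihydroxyphenyl in place of 3,4-dimethoxyphenyl on an oxygen on an aromatic ring), 3,4-dihydroxyphenyl in place of 3,4-dimethoxyphenyl on an oxygen on an aromatic ring. Among the measured compounds shown here, the only measured step (a 1.0-fold lower number from compound 1 to compound 2 (0.01 log units; within the scatter)) lies on an amine nitrogen, so it does not test this change, and no measured compound carries the 3,4-dihydroxyphenyl group. A modest move toward a lower number in this assay is therefore expected, with wide uncertainty in both directions. The expected size is a 1.7-fold lower number from compound 1 to compound 3 (0.23 log units; within the scatter) by estimate alone. Compound 3 is estimated at 7000 nM (expected range 2000 nM to 22000 nM).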

Compound 3, half-maximal inhibitory concentration: > 20000 nM
Compound 3 ended at the assay's limit; the forecaster's own chance of this, stated with the estimate: 8%; middle value at least 2.8-fold (0.45 log units) from the limit.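

In this assay, among the compounds shown here, the first step at this position, 3,4-dihydroxyphenyl in place of 3,4-dimethoxyphenyl on an oxygen on an aromatic ring, gives an at least 1.6-fold higher number from compound 1 to compound 3 (0.22 log units; that floor lies within the scatter). Compound 3 gives a limit of the assay and not a number: the limit of > 20000 nM in this assay, at which 1 of the 3 values shown sits. The earlier pair tested only a change on an amine nitrogen, whereas this step shows that the change on the oxygen does not give a lower number, though its floor alone does not carry compound 3 beyond the scatter of compound 1.

As far as these compounds go, how far compound 3 truly lies from compound 1 remains open. Also open, from the compounds shown here alone, are how a phenyl with a single methoxy group or a methylenedioxy ring would read in this place, and whether the same change would give a similar step on the background of compound 2.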